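The compounds below may be only part of what the source reports. "The series", "measured", "known", "first", "only" and "open" are said of these compounds alone.

Measured so far in an ADME assay on microsomes from liver (Homo sapiens) for metabolic stability, read by LC-MS, using NADPH, with stated times of 5 min and 30 min, tested at 1 uM; a lower number here means slower removal, a higher number faster removal of the compound:
compound 1 `Fc1ccc2c(c1CNc1ncc(Oc3ccccc3)c3nncn13)CCO2`: 18 mL.min-1.g-1
compound 2 `CC1(C)CC(=O)N(c2cnc(NCc3c(F)ccc4c3CCO4)n3cnnc23)C1`: 16 mL.min-1.g-1
compound 3 `CN(c1cccnc1)c1cnc(NCc2c(F)ccc3c2CCO3)n2cnnc12`: 80 mL.min-1.g-1

Compound 3 stands highest of the three: a 4.4-fold higher number from compound 1 to compound 3 (0.65 log units; beyond the scatter) and a 5.0-fold higher number from compound 2 to compound 3 (0.70 log units; beyond the scatter) both lie beyond the scatter, whereas a 1.1-fold lower number from compound 1 to compound 2 (0.05 log units; within the scatter) lies within it. Compound 4 `CN(C(=O)c1ccccc1)c1cnc(NCc2c(F)ccc3c2CCO3)n2cnnc12` keeps the core of compound 3 and alters only the group on the nitrogen: benzoyl in place of pyridin-3-yl on a nitrogen on an aromatic ring. For the measured compounds named here, no measured step involves a benzoyl group, so only indirect evidence bears on it: the two steps in which methyl(pyridin-3-yl)amino enters both run upward by a modest amount, and replacing it with anything else has so far given lower numbers. A modest downward step in this assay is therefore expected, with wide uncertainty. Compound 4 is estimated at 35 mL.min-1.g-1 (range 12 mL.min-1.g-1 to 100 mL.min-1.g-1), an expected step of a 2.3-fold lower number from compound 3 to compound 4 (0.36 log units; beyond the scatter).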

Compound 4, intrinsic clearance in microsomes: > 300 mL.min-1.g-1
Compound 4: no number, only a limit (the forecaster's own chance of this, stated with the estimate: 5%); at least 8.5-fold (0.93 log units) between middle value and limit.
By their numbers in this assay, from the lowest: compounds 2 and 1 (each within the scatter of the next); then compound 3. At a limit, above all of these: compound 4.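

Compound 4 has no number in this assay, only a limit: the limit of > 300 mL.min-1.g-1 in this assay, at which 1 of the 4 values shown sits. On a nitrogen on an aromatic ring, benzoyl in place of pyridin-3-yl gives an at least 3.7-fold higher number from compound 3 to compound 4 (0.57 log units; beyond the scatter), so the group on this nitrogen alone can move the number well beyond the scatter. Benzoyl(methyl)amino also stands far from the other groups on the aromatic carbon, with an at least 18-fold higher number from compound 2 to compound 4 (1.27 log units; beyond the scatter) and an at least 16-fold higher number from compound 1 to compound 4 (1.22 log units; beyond the scatter).

As far as these compounds go, the full size of these steps stays open. Also open, from the compounds shown here alone, is whether the step follows the carbonyl or the carbon-only ring, a question an acetyl group on this nitrogen would address.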